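The source may hold more compounds than are shown below. What is called first, only, known or untested is meant among the compounds shown, and "the series" means these compounds.

Of the compounds shown here, three built on a shared core have been measured in an assay on CHO cells for displacement of a labelled ligand from adenosine receptor A3 (Homo sapiens), read by scintillation counting; a lower number here means a stronger inhibitor, a higher number a weaker inhibitor. Compound 1 `O=C(Nc1nc(-c2ccccc2)nc2c1nnn2Cc1ccccc1)c1ccccc1C(F)(F)F` gives 560 nM, compound 2 `O=C(Nc1nc(-c2ccccc2)nc2c1nnn2Cc1ccccc1)C1CCCC1` gives 4690 nM, and compound 3 `O=C(Nc1nc(-c2ccccc2)nc2c1nnn2Cc1ccccc1)c1ccc(C(F)(F)F)cc1` gives 4210 nM. Compound 3 thus stands second highest of the three numbers: the step of a 7.5-fold higher number from compound 1 to compound 3 (0.88 log units; beyond the scatter) set it well apart from compound 1, while the step of a 1.1-fold lower number from compound 2 to compound 3 (0.05 log units; within the scatter) left it indistinguishable from compound 2. Compound 4 `O=C(Nc1nc(-c2ccccc2)nc2c1nnn2Cc1ccccc1)c1ccc(Cl)cc1` differs from compound 3 by one change: chloro in place of trifluoromethyl on an aromatic carbon. Within the data shown here, none of the measured steps changes a group at this place on the ring, so they give no direct guide, and the step of an 8.4-fold higher number from compound 1 to compound 2 (0.92 log units; beyond the scatter) concerns another part of the molecule. With no evidence of a shift, the expected step of a 1.2-fold lower number from compound 3 to compound 4 (0.08 log units; within the scatter) is none beyond the scatter. Compound 4 is therefore estimated at 3500 nM, within 1200 nM to 10000 nM.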

Compound 4, inhibition constant: 3550 nM
Compound 4: middle estimate off by 1.0-fold (0.01 log units), on the low side; the range from low to high includes it.
By their numbers in this assay, from the lowest: compound 1; then compounds 4, 3 and 2 (each within the scatter of the next).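

At this position, chloro in place of trifluoromethyl leaves binding unchanged within the scatter (a 1.2-fold lower number from compound 3 to compound 4 (0.07 log units; within the scatter)), so these two groups cannot be told apart here. The 4-chlorophenyl group also reads the same as cyclopentyl (a 1.3-fold lower number from compound 2 to compound 4 (0.12 log units; within the scatter)), and it remains clearly weaker than 2-(trifluoromethyl)phenyl (a 6.3-fold higher number from compound 1 to compound 4 (0.80 log units; beyond the scatter)). No independent evidence bears on this result. From the compounds shown here alone, whether an amine or a carboxylic acid on this aromatic carbon would move the number remains open.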